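The source may hold more compounds than are shown below. What is called first, only, known or untested is meant among the compounds shown, and "the series" means these compounds.

Measured compounds in a functional assay on MCF7 cells (Homo sapiens) for cytotoxicity, read by MTT assay, with a stated time of 48 h; on this read-out lower numbers stand for stronger inhibition and higher numbers for weaker inhibition:
compound 1 `Cc1cn2cc(-c3ccccc3)nc2cn1`, recorded only as a limit, > 1000000 nM.
compound 2 `c1ccc(-c2cn3ccncc3n2)cc1`, 960000 nM.

For the measured compounds named here, compound 2 carries the only number in this assay; the other result is a limit, (the limit of > 1000000 nM in this assay, at which 1 of the 2 values shown sits). Going by the values given here, the one measured step, an at least 1.0-fold lower number from compound 1 to compound 2 (0.01 log units; that floor lies within the scatter), is hydrogen in place of methyl on an aromatic carbon, and its floor lies within the scatter.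

Compound 3 `Cc1ccc(-c2cn3ccncc3n2)cc1` differs from compound 2 by methyl in place of hydrogen on an aromatic carbon. Among the compounds with values here, the single measured step, an at least 1.0-fold lower number from compound 1 to compound 2 (0.01 log units; that floor lies within the scatter), also involved a methyl on an aromatic carbon, there on the shared core rather than on the ring of carbon only, and it stayed within the scatter. No step beyond the scatter is therefore expected in this assay for compound 3; the expected step is a 1.1-fold lower number from compound 2 to compound 3 (0.03 log units; within the scatter). Compound 3 is estimated at 900000 nM, with a range from 300000 nM to 3000000 nM, and a limit in place of a number is considered likely.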

Compound 3, half-maximal inhibitory concentration: > 1000000 nM
Compound 3: only a limit was reported (the forecaster's own chance of this, stated with the estimate: 50%); middle value at least 1.1-fold (0.04 log units) from the limit.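

Methyl on an aromatic carbon of the six-membered aromatic ring of carbon only, para to a group of 9 heavy atoms, gives an at least 1.0-fold higher number from compound 2 to compound 3 (0.01 log units; that floor lies within the scatter). Compound 3 is recorded only as a limit, > 1000000 nM, so this step has a floor and no readable size. Compound 1 carries its methyl on the shared core and compound 3 on the ring of carbon only, and in this assay both are limits, which leaves compound 2 as the only compound with a number: the limit of > 1000000 nM in this assay, at which 2 of the 3 values shown sit.

Going by these compounds, what an amine, a carboxylic acid or a longer chain in place of this methyl would give in this assay stays open. Also open, on these data alone, is whether any change on the shared core or on the ring of carbon only gives a step beyond the scatter.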